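Hydroxypiperidinyl in place of chlorophenoxy on the acylguanidine core

The compounds below may be only part of what the source reports. "The series", "measured", "known", "first", "only" and "open" are said of these compounds alone.

Compound 1 `Cc1cc(SC(C)(C)C)c(S(C)(=O)=O)cc1C(=O)N=C(N)N`: 22 nM
Compound 2 `Cc1cc(Oc2ccc(Cl)cc2)c(S(C)(=O)=O)cc1C(=O)N=C(N)N`: 13 nM

For the measured compounds named here, in a functional assay for inhibition of sodium/hydrogen exchanger (Oryctolagus cuniculus) (a lower number here means a stronger inhibitor, a higher number a weaker inhibitor), compound 2 gives 13 nM, the lowest of the two numbers known; compound 1 gives 22 nM, and the step of a 1.7-fold lower number from compound 1 to compound 2 (0.23 log units; within the scatter) lies within the scatter. Compound 3 `Cc1cc(N2CCCC(O)C2)c(S(C)(=O)=O)cc1C(=O)N=C(N)N` carries the change (3-hydroxypiperidin-1-yl in place of 4-chlorophenoxy on an aromatic carbon), on the carbon that bears the methylsulfonyl group as a neighbour. Going by the values given here, the only measured step, a 1.7-fold lower number from compound 1 to compound 2 (0.23 log units; within the scatter), bears on it just in that the same position was varied there; it was small, and it did not involve a non-aromatic ring with a hydrogen-bond donor. There is therefore no shown step that would predict a change beyond the scatter, and the estimate for compound 3 is held close to compound 2 with a wide range: compound 3 is expected at 30 nM, between 7 nM and 150 nM, which means an estimated step of a 2.3-fold higher number from compound 2 to compound 3 (0.36 log units; beyond the scatter) in this assay.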

Compound 3, half-maximal inhibitory concentration: 30 nM
Beside the measured number, compound 3's estimate shows no gap at the digits printed; the measured number falls inside the stated range.
By their numbers in this assay, from the lowest: compounds 2, 1 and 3 (each within the scatter of the next, the first and the last beyond it).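

In this assay the carbon ortho to a methylsulfonyl group now shows its first step beyond the scatter: a 2.3-fold higher number from compound 2 to compound 3 (0.36 log units; beyond the scatter) is modest, and it comes with a non-aromatic ring carrying a hydrogen-bond donor in place of an aromatic ring of carbon only. Against (tert-butyl)sulfanyl, the same 3-hydroxypiperidin-1-yl gives a 1.4-fold higher number from compound 1 to compound 3 (0.13 log units; within the scatter) and so cannot be told apart from that group, which shows that this position accepts a ring of this kind with little change in the number. No measurement given here explains either step.

On these data alone, what a plain piperidin-1-yl ring without the hydroxyl, or a 4-hydroxypiperidin-1-yl ring, would give on this carbon remains open. So does whether a carboxylic acid or a longer amine chain there would keep the number in the same range in this assay as well.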